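Shortening the chlorinated chain to a single bromo group

This account rests on a few compounds, and the source may have more. Where it says the series, first, only, none or still open, it means among the compounds named here.

In a functional assay on KYSE-450 cells (Homo sapiens) for inhibition, read by MTT assay, with a stated time of 48 h (on this read-out higher numbers stand for weaker inhibition and lower numbers for stronger inhibition), compound 1 `COc1ccc(CN(C(=O)CCCl)c2cc(OC)c(OC)c(OC)c2)cc1O` gives 110 nM, while compound 2 `COc1ccc(CN(C(=O)CCCCCl)c2cc(OC)c(OC)c(OC)c2)cc1O` gives 770 nM, the higher of the two numbers and so the weaker inhibition. Compound 3 `COc1ccc(CN(C(=O)CBr)c2cc(OC)c(OC)c(OC)c2)cc1O` changes that chain: bromo in place of 3-chloropropyl on a saturated chain carbon bound to a carbonyl carbon. Among the compounds with values here, the one measured step that bears on this is a 7.0-fold higher number from compound 1 to compound 2 (0.85 log units; beyond the scatter), where a longer chain came with a higher number. Within the data shown here, compound 3 loses chain length instead, so a lower number is expected, although no measured compound carries bromo. The expected change is a 9.6-fold lower number from compound 2 to compound 3 (0.98 log units; beyond the scatter), towards stronger inhibition. For compound 3 the estimated value is 80 nM, with an expected range of 20 nM to 300 nM.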

Compound 3, half-maximal inhibitory concentration: 120 nM
Estimate against measurement, compound 3: 1.5-fold (0.18 log units) below; the range from low to high includes it.
By their numbers in this assay, from the lowest: compounds 1 and 3 (each within the scatter of the next); then compound 2.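

In this assay the change gives a 6.4-fold lower number from compound 2 to compound 3 (0.81 log units; beyond the scatter) and so stronger inhibition: on this saturated chain carbon bound to a carbonyl carbon, bromo can stand in place of 3-chloropropyl. The comparison with the shorter chlorinated chain gives a 1.1-fold higher number from compound 1 to compound 3 (0.04 log units; within the scatter) and so no real difference: here bromo and chloromethyl cannot be told apart. Nothing shown here explains either step.

Still open, on these data alone, is whether a chain end without halogen, such as a plain methyl or an amine, would hold this level. Whether fluoro or iodo would match bromo is also unanswered.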